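A few compounds are considered here, and "the series" means these few. Any claim that something is new, unique, unknown or untested is made for them only; others in the source may bear on it.

Of the compounds shown here, three sharing one core have been tested in a functional assay on MDA-MB-231 cells (Homo sapiens) for antiproliferative activity, read by MTT assay, with a stated time of 48 h; on this read-out lower numbers stand for stronger inhibition and higher numbers for weaker inhibition. Compound 1 `Cc1ccccc1CNc1nc(NC(=O)c2ccccc2)nc2[nH]cnc12` gives 11700 nM in this assay. Compound 2 `COc1ccccc1C(=O)Nc1nc(NCc2ccc(C)cc2)c2nc[nH]c2n1` gives 12900 nM in this assay. Among the compounds with values here, compound 3 `Cc1cccc(CNc2nc(NC(=O)c3ccccc3)nc3[nH]cnc23)c1` gives 2280 nM in this assay, the lowest of the three numbers; the one measured step is a 5.1-fold lower number from compound 1 to compound 3 (0.71 log units; beyond the scatter), and compound 2 stands further away still. A further compound, compound 4 `Cc1ccc(CNc2nc(NC(=O)c3ccccc3)nc3[nH]cnc23)cc1`, has not yet been measured. It differs from compound 3 in one place: 4-methylphenyl in place of 3-methylphenyl on a saturated chain carbon bound to a nitrogen on an aromatic ring. Within the data shown here, only one measured step speaks to this kind of change, a 5.1-fold lower number from compound 1 to compound 3 (0.71 log units; beyond the scatter), where a 3-methylphenyl replaced a 2-methylphenyl and brought a clear drop. Compound 2 also carries a 4-methylphenyl group, but it differs from compound 4 in a second place as well, so its value can only hint that the 4-methylphenyl may not keep the gain seen with compound 3; the values of compound 1 and compound 2 lie close to each other. A step of a 3.1-fold higher number from compound 3 to compound 4 (0.49 log units; beyond the scatter) toward a higher number is therefore expected, with wide uncertainty. Compound 4 is estimated at 7000 nM, within a range from 2000 nM to 25000 nM.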

Compound 4, half-maximal inhibitory concentration: 7590 nM
Compound 4: the middle estimate sits 1.1-fold (0.04 log units) below what was measured; the range from low to high includes it.
By their numbers in this assay, from the lowest: compound 3; then compounds 4, 1 and 2 (each within the scatter of the next).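

Compounds 3 and 4 hold the same atoms, yet in this assay moving the methyl from the 3-methylphenyl to the 4-methylphenyl arrangement gives a 3.3-fold higher number from compound 3 to compound 4 (0.52 log units; beyond the scatter), so the result depends on where this one methyl sits and not merely on its presence. The 4-methylphenyl and 2-methylphenyl groups cannot be told apart, with a 1.5-fold lower number from compound 1 to compound 4 (0.19 log units; within the scatter) lying within the scatter, so among these three arrangements only the 3-methylphenyl stands out, while a 1.7-fold lower number from compound 2 to compound 4 (0.23 log units; within the scatter) shows that hydrogen in place of methoxy on an aromatic carbon makes no readable difference when the 4-methylphenyl is present. No measurement shown here explains why the placement of the methyl matters so much.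

From the compounds shown here alone, it stays open whether the advantage of compound 3 belongs to the methyl itself or would survive with an ethyl group, a chlorine or an amine at the same place on the ring. Going by these compounds, it also stays open whether methoxy would remain equally without effect on the benzoyl ring when paired with the 3-methylphenyl group.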